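The source may report more compounds than this note shows. Statements on the series, on what has been measured and on what is new or still open speak of the compounds shown alone.

Measured in a functional assay on V79 cells (Cricetulus griseus) for cytotoxicity, read by colony formation; on this read-out higher numbers stand for weaker inhibition and lower numbers for stronger inhibition:
- compound 1 `O=C(O)c1cn(C2CC2)c2cc(N3CCCC3)c(F)cc2c1=O`: 38 ug/mL
- compound 2 `NC1CCN(c2cc3c(cc2F)c(=O)c(C(=O)O)cn3C2CC2)CC1`: 230 ug/mL

Of these two compounds, compound 2 has the higher number and so the weaker inhibition in this assay. Compound 3 `NC1CCCN(c2cc3c(cc2F)c(=O)c(C(=O)O)cn3C2CC2)C1` has the same atoms as compound 2, joined differently: 3-aminopiperidin-1-yl in place of 4-aminopiperidin-1-yl on an aromatic carbon. The exchange takes place on an aromatic carbon, ortho to a fluoro group.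

Among the measured compounds shown here, only one measured step bears on it: a 6.1-fold higher number from compound 1 to compound 2 (0.78 log units; beyond the scatter). That step involved the same place but a different pair of groups, so it offers only a loose guide. For the measured compounds named here, no pair of isomers has been measured, and the direction remains open. A small step is expected in this assay, probably within the scatter and slightly downward. The estimate for compound 3 is 150 ug/mL, with an expected range of 50 ug/mL to 400 ug/mL. This expectation means a 1.5-fold lower number from compound 2 to compound 3 (0.19 log units; within the scatter).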

Compound 3, half-maximal inhibitory concentration: > 500 ug/mL
Compound 3 gave a limit, no number; the forecaster's own chance of this, stated with the estimate: 10%; at least 3.3-fold (0.52 log units) between middle value and limit.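

Compound 3 gives no number in this assay, only a limit: the limit of > 500 ug/mL in this assay, at which 1 of the 3 values shown sits. With the same atoms joined differently, 3-aminopiperidin-1-yl in place of 4-aminopiperidin-1-yl on this aromatic carbon, ortho to a fluoro group, gives an at least 2.1-fold higher number from compound 2 to compound 3 (0.33 log units; beyond the scatter), so the direction between these isomers is now known: weaker inhibition for the 3-amino isomer, a difference that the step between compound 1 and compound 2 could not reveal. Set against pyrrolidin-1-yl, the same group gives an at least 13-fold higher number from compound 1 to compound 3 (1.11 log units; beyond the scatter), which widens the span of this position in the series.

Going by these compounds, how far compound 3 lies past its limit remains open, so the true size of both steps is unknown. Also open, on these data alone, is how piperazin-1-yl or an open-chain amine such as dimethylamino would read at this aromatic carbon.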